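This account rests on a few compounds, and the source may have more. Where it says the series, first, only, none or still open, it means among the compounds named here.

Measured compounds:
Compound 1, `CCOC(=O)C1=Cc2ccccc2OC1(OCc1cc(-c2ccc(C)cc2)no1)C(F)(F)F`, in a functional assay on HeLa cells (Homo sapiens) for inhibition, read by MTT assay, with a stated time of 24 h (a lower number here means a stronger inhibitor, a higher number a weaker inhibitor), gives a value that is a limit of the assay, > 150000 nM.
Compound 2, `CCOC(=O)C1=Cc2ccccc2OC1(OCc1cc(-c2ccc([N+](=O)[O-])cc2)no1)C(F)(F)F`, likewise gives only a limit in this assay, > 150000 nM.
Compound 3, `CCOC(=O)C1=Cc2ccccc2OC1(OCc1cc(-c2cccc(C(F)(F)F)c2)no1)C(F)(F)F`, gives a number in this assay, 21400 nM.

Compound 3 is thus the only one of the three with a measured number; the other two values sit at the assay limit (the limit of > 150000 nM in this assay, at which 2 of the 3 values shown sit). The unmeasured compound 4 is `CCOC(=O)C1=Cc2ccccc2OC1(OCc1cc(-c2ccc(F)cc2)no1)C(F)(F)F`. It differs from compound 3 in one place: 4-fluorophenyl in place of 3-(trifluoromethyl)phenyl on an aromatic carbon.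

For the measured compounds named here, two measured steps bear on this change, both running toward compound 3 from a para-substituted phenyl. The step of an at least 7.0-fold lower number from compound 1 to compound 3 (0.84 log units; beyond the scatter) and the step of an at least 7.0-fold lower number from compound 2 to compound 3 (0.84 log units; beyond the scatter) both show that replacing a para-substituted phenyl with the 3-(trifluoromethyl)phenyl brought the number down from the limit to a measurable value. Compound 4 carries a para-substituted phenyl again, the 4-fluorophenyl, so the step from compound 3 is expected to run the other way, back toward the limit, as a 5.1-fold higher number from compound 3 to compound 4 (0.71 log units; beyond the scatter). Compound 4 is therefore estimated to give 110000 nM in this assay, within a range from 30000 nM to 350000 nM, with a fair chance that only a limit is reported.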

Compound 4, half-maximal inhibitory concentration: 42300 nM
For compound 4 the middle estimate is 2.6-fold (0.42 log units) above the measured one; the range from low to high includes it.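

With the 4-fluorophenyl group in place of the 3-(trifluoromethyl)phenyl group, this assay shows a 2.0-fold higher number from compound 3 to compound 4 (0.30 log units; within the scatter), so the two groups cannot be told apart here and a measured number at this position is not tied to the 3-(trifluoromethyl)phenyl group. The atom at the 4-position of the phenyl group also makes a difference among the compounds that carry a group there: fluoro in place of nitro gives an at least 3.5-fold lower number from compound 2 to compound 4 (0.54 log units; beyond the scatter), and fluoro in place of methyl gives an at least 3.5-fold lower number from compound 1 to compound 4 (0.54 log units; beyond the scatter). Both of these steps are open-ended, because compound 1 and compound 2 each give only a limit of the assay: the limit of > 150000 nM in this assay, at which 2 of the 4 values shown sit.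

From the compounds shown here alone, what remains open is whether a different group on this phenyl, such as an amine or a carboxylic acid, would bring the number clearly below that of compound 3 and compound 4. Also open, going by these compounds, is whether a saturated group such as cyclohexyl could stand in place of the phenyl group at this aromatic carbon, next to the ring nitrogen, and still give a measured number.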